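Thiazolopyrimidine anilines: para substituent change at adenosine A3

The source may hold more compounds than are shown below. What is called first, only, known or untested is meant among the compounds shown, and "the series" means these compounds.

Compound 1 `COc1ccc(Nc2nc3c(Cl)ncnc3s2)cc1`: 5880 nM
Compound 2 `O=[N+]([O-])c1ccc(Nc2nc3c(N4CCCC4)ncnc3s2)cc1`: 3630 nM

In an assay on CHO cells for displacement of a labelled ligand from adenosine receptor A3 (Homo sapiens), read by scintillation counting, with a stated time of 3 h (a higher number here means a weaker inhibitor, a lower number a stronger inhibitor), compound 2 gives 3630 nM, the lower of the two numbers, while compound 1 gives 5880 nM, a difference that lies within the scatter, so neither compound can be called the stronger inhibitor.

Compound 3 `Clc1ccc(Nc2nc3c(N4CCCC4)ncnc3s2)cc1` differs from compound 2 in one place: chloro in place of nitro on an aromatic carbon. Going by the values given here, no comparable step among the measured compounds is available, and both measured values sit close together at weak binding. No shift beyond the scatter is expected for compound 3 in this assay, with the estimated step of a 1.1-fold higher number from compound 2 to compound 3 (0.04 log units; within the scatter) accordingly small. The estimate for compound 3 is 4000 nM, with a range from 1500 nM to 12000 nM.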

Compound 3, inhibition constant: 4260 nM
Compound 3: middle estimate off by 1.1-fold (0.03 log units), on the low side; measured number inside the range.
By their numbers in this assay, from the lowest: compounds 2, 3 and 1 (each within the scatter of the next).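

In this assay, chloro in place of nitro on an aromatic carbon, para to a large group, gives a 1.2-fold higher number from compound 2 to compound 3 (0.07 log units; within the scatter). Going by these compounds alone, this is the first one-place comparison, and at this position the assay does not separate the two groups. No measurement shown bears on why the two groups read alike.

Open, going by these compounds, is whether an amine or a carboxylic acid on this aromatic carbon would give a step beyond the scatter. Also open, on these data alone, is whether a hydrogen there would read like nitro and chloro.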